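The source may hold more compounds than are shown below. What is called first, only, known or untested is meant among the compounds shown, and "the series" means these compounds.

Measured so far in an assay for displacement of a labelled ligand from Rap guanine nucleotide exchange factor 3 (Homo sapiens), read by cAMP accumulation, with a stated time of 4 h; on this read-out lower numbers stand for stronger inhibition and higher numbers for weaker inhibition:

Compound 1 `COc1ccc2ccc(OCC(=O)NS(=O)(=O)c3ccc4ccccc4c3)cc2c1`: 2200 nM
Compound 2 `O=C(COc1ccc2ccccc2c1)NS(=O)(=O)c1ccc([N+](=O)[O-])c(F)c1`: 32500 nM

Compound 1 stands at the lowest of the two numbers in this assay. Compound 2 gives a number higher by a margin that lies beyond the usual scatter, so compound 2 is the weaker inhibitor of the pair. Within the data shown here, compound 2 differs from compound 1 in more than one place, so no clean single step between measured compounds is available.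

Compound 3 `COc1ccc2ccc(OCC(=O)NS(=O)(=O)c3ccc(N)cc3OC)cc2c1` differs from compound 1 by one change: a group of 9 heavy atoms (7 carbon, 1 nitrogen, 1 oxygen; one six-membered aromatic ring of carbon only) in place of a group of 10 heavy atoms (10 carbon; 2 six-membered aromatic rings of carbon only), on a sulfonyl sulfur. Among the measured compounds shown here, the only comparison at hand, compound 1 against compound 2, shows that moving away from the shared core of compound 1 at this position can cost a good deal of inhibition, though that comparison carries a second change as well. For compound 3 the expected step from compound 1, a 3.0-fold higher number from compound 1 to compound 3 (0.47 log units; beyond the scatter), is a loss of inhibition beyond the scatter. Compound 3 is therefore estimated at 6500 nM, with a likely range from 2000 nM to 22000 nM.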

Compound 3, half-maximal inhibitory concentration: 900 nM
Compound 3: middle estimate off by 7.2-fold (0.86 log units), on the high side; measured number outside the range, below it.
By their numbers in this assay, from the lowest: compound 3; then compound 1; then compound 2.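

On the sulfonyl sulfur, the two-ring naphthalen-2-yl group of compound 1 turns out not to be required for inhibition in this assay. Replacing it with a group that has one six-membered aromatic ring, plus nitrogen and oxygen, gives a 2.4-fold lower number from compound 1 to compound 3 (0.39 log units; beyond the scatter), a modest gain, so a smaller group at this position can do better, and change here need not cost inhibition. Nothing measured here explains this gain.

The entering group differs from the naphthalen-2-yl group in several ways at once, so this single step cannot show whether the ring count, the nitrogen or the oxygen matters most. A ring bearing only an amine or only a methoxy group, or a carboxylic acid in place of the amine, would help separate these features.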